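The source may report more compounds than this note shows. Statements on the series, on what has been measured and on what is new or still open speak of the compounds shown alone.

Working notes on the series. In an assay on isolated protein for inhibition of G protein-coupled receptor kinase 6 (Homo sapiens), read by scintillation counting, radiometric assay and 33P incorporation, with a stated time of 80 min, in the presence of a further agent that is not named here (a lower number here means a stronger inhibitor, a higher number a weaker inhibitor), compound 1 `CCc1cc(Nc2nc(N[C@@H](C)c3ccc(F)cc3)nc3ccccc23)n[nH]1` gives 120 nM, the lowest number among the three measured compounds. Compound 3 `CCc1cc(Nc2nc(N[C@@H](C)c3ccc(F)cc3)nc3ccc(OC)cc23)n[nH]1` gives 140 nM, and the step of a 1.2-fold higher number from compound 1 to compound 3 (0.07 log units; within the scatter) lies within the scatter. Compound 2 `CCc1cc(Nc2nc(N[C@@H](C)c3ccc(OC)cc3)nc3ccccc23)n[nH]1` gives 290 nM, and the step of a 2.4-fold higher number from compound 1 to compound 2 (0.38 log units; beyond the scatter) is beyond the scatter. Compound 4 `CCc1cc(Nc2nc(N[C@H](C)c3ccc(F)cc3)nc3ccccc23)n[nH]1` differs from compound 1 only in configuration: the two compounds have the same atoms and bonds and differ only in configuration as drawn: 1 of 1 stereo elements differ; a stereocentre at a saturated chain carbon is drawn S in compound 1 and R in compound 4. Neither measured step bears on this change; both vary a group on an aromatic carbon while the stereocentre keeps the same drawing. The data therefore give no step size or direction for an inversion at this carbon, and the estimate must carry a wide range. Compound 4 is expected to give 500 nM, between 100 nM and 3000 nM, an expected step of a 4.2-fold higher number from compound 1 to compound 4 (0.62 log units; beyond the scatter).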

Compound 4, half-maximal inhibitory concentration: 1400 nM
Beside the measured number, compound 4's estimate is 2.8-fold (0.45 log units) below it; low and high end bracket the measured number.
By their numbers in this assay, from the lowest: compounds 1 and 3 (each within the scatter of the next); then compound 2; then compound 4.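

The stereocentre at the saturated chain carbon matters in this series: going from S to R gives a 12-fold higher number from compound 1 to compound 4 (1.07 log units; beyond the scatter), a larger step than either change on an aromatic carbon. This step can be assigned to that carbon alone because nothing else separates the pair: the fact that compounds 1 and 4 differ only in the configuration as drawn. Within this pair, the S drawing gives the stronger inhibitor.

Going by these compounds, whether the methoxy compounds 2 and 3 show the same preference on inversion stays open. Also open, on these data alone, is how the stereocentre responds when its methyl group gives way to a propyl chain or an amine.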